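Swapping Phenyl for Methyl on the Amide Ring

The compounds below may be only part of what the source reports. "The series", "measured", "known", "first", "only" and "open" are said of these compounds alone.

Compound 1 `Cc1ccc(Nc2ncc3c(n2)N(C)C(=O)N(c2cc(NC(=O)c4cccc(C(F)(F)F)c4)ccc2C)C3)cc1C`: 17 nM
Compound 2 `Cc1ccc(Nc2ncc3c(n2)N(C)C(=O)N(c2cc(NC(=O)c4cccc(-c5ccccc5)c4)ccc2C)C3)cc1N`: 23 nM
Compound 3 `Cc1ccc(Nc2ncc3c(n2)N(C)C(=O)N(c2cc(NC(=O)c4cc(C(C)(C)C)cc(C(C)(C)C)c4)ccc2C)C3)cc1N`: 1300 nM

These three compounds were tested in a functional assay on K562 cells (Homo sapiens) for antiproliferative activity, read by CellTiter-Glo and CCK-8 assay, with a stated time of 72 h; on this read-out lower numbers stand for stronger inhibition of growth and higher numbers for weaker inhibition of growth. Compound 2 gives the second highest of the three numbers; its value and that of compound 1 lie within the scatter of each other, while compound 3 sits far higher, beyond the scatter. Compound 4 `Cc1cccc(C(=O)Nc2ccc(C)c(N3Cc4cnc(Nc5ccc(C)c(N)c5)nc4N(C)C3=O)c2)c1` has not been measured. It differs from compound 2 by methyl in place of phenyl on an aromatic carbon. Within the data shown here, no measured pair shows this exact step, so the expectation rests on the spread among the three. A one-carbon group replaces the phenyl; compound 1, with a trifluoromethyl rather than a phenyl on that ring, gives 17 nM. The step from compound 2 to compound 4 is expected to be a 2.0-fold higher number from compound 2 to compound 4 (0.29 log units; within the scatter), a modest rise at the edge of the scatter. Compound 4 is estimated at 45 nM, between 15 nM and 140 nM.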

Compound 4, concentration for 50% growth inhibition: 68.8 nM
Beside the measured number, compound 4's estimate is 1.5-fold (0.18 log units) below it; the measured number falls inside the stated range.
By their numbers in this assay, from the lowest: compounds 1 and 2 (each within the scatter of the next); then compound 4; then compound 3.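

Replacing the phenyl with a methyl, meta to a large group, with everything else in the molecule unchanged, gives a 3.0-fold higher number from compound 2 to compound 4 (0.48 log units; beyond the scatter), meaning weaker inhibition of growth. Among these compounds, this is the first direct reading of this change, and it shows that the step is modest: compound 4 keeps much of its activity without the second aromatic ring. No measurement available here explains the step.

The compounds shown leave open how an amine, a methoxy group or a carboxylic acid would behave at this position. They also leave open what a longer chain, such as ethyl or propyl, would give between methyl and phenyl.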